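The source may hold more compounds than are shown below. What is called first, only, known or untested is meant among the compounds shown, and "the series" means these compounds.

Working notes on the series. In a functional assay on IMR-32 cells (Homo sapiens) for cytotoxicity (on this read-out higher numbers stand for weaker inhibition and lower numbers for stronger inhibition), compound 1 `COc1ccc(C2C(O)C(=O)N2c2cc(OC)c(OC)c(OC)c2)cc1` gives 33 nM, and compound 2 `COc1ccc(C2C(O)C(=O)N2c2cc(OC)c(OC)c(OC)c2)cc1N` gives 37 nM; 38.3 nM (2 entries); the repeated entries of compound 2 the several entries of compound 2 in this assay, 37 nM; 38.3 nM (2 entries) sit close together. Compound 3 `COc1cc(N2C(=O)C(OC(C)=O)C2c2ccc([N+](=O)[O-])o2)cc(OC)c1OC` gives 811 nM in this assay and so stands at the high end of the two numbers available, with compound 1 the nearest and lower by a margin beyond the scatter; compound 2 contributes no single number for this comparison. Compound 3 differs from compound 1 and compound 2 at more than one place, so the gap cannot be tied to any one feature.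

Compound 4 `COc1cc(N2C(=O)C(O)C2c2ccc([N+](=O)[O-])o2)cc(OC)c1OC` is not yet measured. It differs from compound 3 by hydrogen in place of acetyl on an oxygen on a saturated carbon, so that the acetoxy of compound 3 becomes a hydroxy. Going by the values given here, no measured pair shows this change on its own, and nothing measured speaks to its size. The expected step of a 1.6-fold lower number from compound 3 to compound 4 (0.21 log units; within the scatter) is small and downward, close to the scatter. For compound 4 the expected value in this assay is 500 nM, within a range from 150 nM to 2000 nM.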

Compound 4, half-maximal inhibitory concentration: > 1000 nM
Compound 4: no number, only a limit (the forecaster's own chance of this, stated with the estimate: 5%); at least 2.0-fold (0.30 log units) between middle value and limit.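

In this assay compound 4 carries only a limit of the assay, not a number: the limit of > 1000 nM in this assay, at which 1 of the 4 values shown sits. Read against that limit, the acetoxy to hydroxy change gives an at least 1.2-fold higher number from compound 3 to compound 4 (0.09 log units; that floor lies within the scatter), so this change on the oxygen is not shown to move the read-out, and its true size cannot be read. Going by these compounds alone, with the hydroxy held constant, 5-nitrofuran-2-yl in place of 4-methoxyphenyl on a saturated ring carbon gives an at least 30-fold higher number from compound 1 to compound 4 (1.48 log units; beyond the scatter), the first change tied to one place and the first beyond the scatter.

On these data alone, whether acetoxy to hydroxy behaves the same way with 4-methoxyphenyl on that ring carbon stays open. So does what an amine or a butyryl group would give on this saturated carbon.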